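Chloro in place of hydrogen on the benzyl ring

This account rests on a few compounds, and the source may have more. Where it says the series, first, only, none or still open, it means among the compounds named here.

Compound 1 `Cn1cnnc1SCC(=O)Nc1ccc(-c2nc(-c3ccccc3)c(-c3ccccc3)n2C)cc1`: 86.1%
Compound 2 `CN(C)/C=C/N1CCN(CC(=O)Nc2ccc(-c3nc(-c4ccccc4)c(-c4ccccc4)n3C)cc2)CC1`: 29.8%
Compound 3 `Cn1c(-c2ccc(NC(=O)CN3CCN(Cc4ccccc4)CC3)cc2)nc(-c2ccccc2)c1-c1ccccc1`: 40%

In a functional assay on HT-29 cells (Homo sapiens) for cytotoxicity, read by MTT assay, with a stated time of 24 h, tested at 32 ug/mL (on this read-out higher numbers stand for a stronger effect at the one concentration tested and lower numbers for a weaker effect), compound 3 stands second among the three measured compounds, its nearest neighbour being compound 2 and its furthest compound 1. Compound 4 `Cn1c(-c2ccc(NC(=O)CN3CCN(Cc4ccc(Cl)cc4)CC3)cc2)nc(-c2ccccc2)c1-c1ccccc1` differs from compound 3 by a single change: chloro in place of hydrogen on an aromatic carbon. Going by the values given here, no measured step swaps a hydrogen for a chloro; the closest is a number 10.2 percentage points higher from compound 2 to compound 3 (beyond the scatter), which altered the whole group on the ring amine nitrogen, while a number 56.3 percentage points lower from compound 1 to compound 2 (beyond the scatter) replaced the entire side group on the chain carbon. Adding one chlorine to a ring that is already present is a far smaller change than either, so a step within the scatter is expected, a number 3 percentage points higher from compound 3 to compound 4 (within the scatter). Compound 4 is therefore estimated at 43%, between 27% and 60%.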

Compound 4, a percentage reported as activity, at one concentration (the size of the read-out at that concentration, not a potency): 55.6%
The estimate for compound 4 lay 12.6 percentage points below the measured number, and the stated range covers the measured number.
By their numbers in this assay, from the lowest: compound 2; then compound 3; then compound 4; then compound 1.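

In this assay, the ring of the benzyl group proves responsive to a small edit: one chloro, para to a large group, gives a number 15.6 percentage points higher from compound 3 to compound 4 (beyond the scatter). The earlier steps shown here replaced whole groups, whereas this one shows that a single added atom at this place can move the read-out, and 4-chlorobenzyl gives a number 25.8 percentage points higher from compound 2 to compound 4 (beyond the scatter), a wider gap than benzyl gave. No available evidence accounts for this gain. Going by these compounds, whether the gain is specific to chlorine remains open: fluoro, methyl or methoxy in the same place could test that.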